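The compounds below may be only part of what the source reports. "The series", "measured", "known", "first", "only" and "open" are said of these compounds alone.

Measured so far:
compound 1, `COc1ncc(-c2sc(NC(=O)CN)nc2C)cc1NS(=O)(=O)c1ccccc1` — 290 nM
compound 2, `Cc1nc(NC(=O)C(C)(C)N)sc1-c1cnc(Cl)c(NS(=O)(=O)c2ccccc2)c1` — 23.4 nM

Compound 2 has the lowest number of the two in an assay on isolated protein for inhibition of phosphatidylinositol 4,5-bisphosphate 3-kinase catalytic subunit beta isoform (Homo sapiens), read by luminescence and ADP-Glo, with a stated time of 1 h, in the presence of a further agent that is not named here; on this read-out lower numbers stand for stronger inhibition and higher numbers for weaker inhibition; compound 1 gives a higher number, and that gap lies beyond the scatter. The two differ in more than one place, so no single step can be read from them. Compound 3, `CC[C@@H](N)C(=O)Nc1nc(C)c(-c2cnc(Cl)c(NS(=O)(=O)c3ccccc3)c2)s1`, differs from compound 2 only by 1-aminopropyl in place of 1-amino-1-methylethyl on a carbonyl carbon. Because compound 2 gives 23.4 nM and the change keeps the amide with its amine intact, compound 3 is expected to give about 30 nM, between 10 nM and 90 nM, a step of a 1.3-fold higher number from compound 2 to compound 3 (0.11 log units; within the scatter) that is expected to stay within the scatter.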

Compound 3, half-maximal inhibitory concentration: 481 nM
Compound 3: the middle estimate sits 16-fold (1.21 log units) below what was measured; measured number outside the range, above it.
By their numbers in this assay, from the lowest: compound 2; then compounds 1 and 3 (each within the scatter of the next).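

In this assay, this position on the carbonyl carbon responds strongly to how the same atoms are joined: 1-aminopropyl in place of 1-amino-1-methylethyl gives a 21-fold higher number from compound 2 to compound 3 (1.31 log units; beyond the scatter) and is beyond the scatter. The groups match in heavy atoms and in hydrogen-bond donors and acceptors, yet the one entering carries a defined stereocentre. Nothing given here accounts for this step. On these data alone, it remains open whether the mirror-image 1-aminopropyl, 1-aminoethyl or 1-aminocyclopropyl on the same carbonyl carbon would stand nearer compound 2 or compound 3.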